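The source may report more compounds than this note shows. Statements on the series, on what has been measured and on what is new or still open speak of the compounds shown alone.

Measured compounds:
compound 1, `OC[C@@H](O[C@H]1CCCN(Cc2ncc[nH]2)[C@H]1c1ccccc1)c1cc(Cl)cc(Cl)c1`: 47000 nM
compound 2, `Cc1cc(C(=O)O)ccc1CN1CCC[C@H](O[C@H](CO)c2cc(Cl)nc(Cl)c2)[C@@H]1c1ccccc1`: 2400 nM
compound 3, `Cc1cc(C(=O)O)ccc1CN1CCC[C@H](O[C@H](CO)c2cccc(C(F)(F)F)c2)[C@@H]1c1ccccc1`: 4100 nM

All three values come from an assay on isolated protein for activation of cGMP-dependent protein kinase 1 (Homo sapiens), read by ADP-Glo, with stated times of 30 min and 2 h, in the presence of a further agent that is not named here; on this read-out higher numbers stand for an effect only at larger amounts of compound and lower numbers for an effect already at smaller amounts. Compound 1 has the highest number of the three: compound 3 is nearest to it and compound 2 furthest, and both gaps lie beyond the scatter. Compound 2 and compound 3 share a core with compound 1 but carry a different group on the ring nitrogen and a different aryl group on the ether carbon. Among the measured compounds shown here, the one measured step among them, a 1.7-fold higher number from compound 2 to compound 3 (0.23 log units; within the scatter), concerns only the aryl group on the ether carbon and falls within the scatter.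

Compound 4, `OC[C@@H](O[C@H]1CCCN(Cc2nc3ccccc3[nH]2)[C@H]1c1ccccc1)c1cc(Cl)cc(Cl)c1`, differs from compound 1 in one place: 1H-benzimidazol-2-yl in place of 1H-imidazol-2-yl on a saturated chain carbon bound to an amine nitrogen in a ring. For the measured compounds named here, no measured step touches this position, so nothing separates the effect of the group on the ring nitrogen from the other changes. The lower numbers of compound 2 and compound 3 come with two changes at once and cannot be read as a step at this position.

Compound 4 is therefore expected at 15000 nM in this assay, between 3000 nM and 70000 nM. The step this estimate means, a 3.1-fold lower number from compound 1 to compound 4 (0.50 log units; beyond the scatter), is expected to lean toward a lower number, with a wide range.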

Compound 4, half-maximal effective concentration: 4700 nM
Compound 4: the middle estimate sits 3.2-fold (0.50 log units) above what was measured; measured number inside the range.
By their numbers in this assay, from the lowest: compounds 2, 3 and 4 (each within the scatter of the next); then compound 1.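

In this assay, among the compounds shown here, a 10-fold lower number from compound 1 to compound 4 (1.00 log units; beyond the scatter) is the first measured change at this position with the rest of the molecule held constant, so it shows that the group on a saturated chain carbon bound to an amine nitrogen in a ring affects the number on its own. The two groups have the same count of hydrogen-bond donors and acceptors, and neither carries a net charge; what the change adds in structural terms is a six-membered aromatic ring of carbon only, which goes with a lower number here. Nothing available here explains how that added ring lowers the number, and this single pair cannot establish a mechanism.

The compounds shown leave open whether the same result would follow from other groups at this position, such as a 1H-indol-2-yl group, which has only one ring nitrogen, or a 1-methylbenzimidazol-2-yl group, which has no hydrogen on either ring nitrogen. They also leave open whether 1H-benzimidazol-2-yl would give a lower number than a benzyl group bearing a carboxylic acid on an otherwise identical molecule.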